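This account rests on a few compounds, and the source may have more. Where it says the series, first, only, none or still open, it means among the compounds named here.

Measured so far:
Compound 1, `CCCc1nc2ccccc2c(=O)n1/N=C/c1ccc(Oc2ccc3ccccc3c2)cc1`, in a physicochemical assay for lipophilicity, in phosphate buffer, measured as octanol-water partition (a lower number here means a more polar compound, a higher number a more lipophilic compound), gives 6.12.
Compound 2, `Cc1cc(Oc2ccc(/C=N/n3c(-c4ccccc4)nc4ccccc4c3=O)cc2)ccc1Cl`, in this assay gives 6.52.

Going by the values given here, compound 2 holds the higher of the two numbers; its only neighbour, compound 1, stands lower by a margin beyond the scatter. Compound 3, `O=c1c2ccccc2nc(-c2ccccc2)n1/N=C/c1ccc(Oc2ccc3ccccc3c2)cc1`, has not yet been measured in this assay. It differs from compound 2 in one place: naphthalen-2-yl in place of 4-chloro-3-methylphenyl on an oxygen on an aromatic ring. Among the compounds with values here, no pair of measured compounds shows this exact change on its own, so its size has to be judged from the two numbers alone. Compound 1 carries the same naphthalen-2-yl group on the oxygen and reads lower than compound 2, but it also differs in the group on the shared core, so that gap cannot be laid on the oxygen substituent alone. For compound 3 the step of a number 0.02 log units lower from compound 2 to compound 3 (within the scatter) is expected to stay within the scatter, in either direction. Compound 3 is therefore estimated at 6.5, with a range from 6.1 to 6.9.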

Compound 3, partition coefficient: 6.53
Compound 3: middle estimate off by 0.03 log units, on the low side, and the stated range covers the measured number.
By their numbers in this assay, from the lowest: compound 1; then compounds 2 and 3 (each within the scatter of the next).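

Going by these compounds alone, on the oxygen on an aromatic ring, naphthalen-2-yl in place of 4-chloro-3-methylphenyl gives a step of a number 0.01 log units higher from compound 2 to compound 3 (within the scatter) in this assay, so this pair gives the first direct reading of a change at this place and shows the two groups reading alike there. Compound 3 also isolates the other place, which compound 1 and compound 2 could not do because they differ in two places. With naphthalen-2-yl held on the oxygen, phenyl in place of propyl on an aromatic carbon gives a step of a number 0.41 log units higher from compound 1 to compound 3 (beyond the scatter) and accounts for the gap between these two compounds.

As far as these compounds go, whether a group carrying an amine or a carboxylic acid on that oxygen would read the same remains open, as does whether a longer chain on the aromatic carbon would extend the step seen with propyl. Nothing available here gives a cause for either step.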